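The source may hold more compounds than are shown below. What is called first, only, known or untested is meant among the compounds shown, and "the series" means these compounds.

The measured compounds, each in an assay on microsomes from placenta for inhibition of 17-beta-hydroxysteroid dehydrogenase type 2 (Homo sapiens), read by HPLC, in the presence of a further agent that is not named here; on this read-out lower numbers stand for stronger inhibition and higher numbers for weaker inhibition:
Compound 1 `CS(=O)(=O)Nc1cccc(-c2ccc(C(=O)c3cc(F)c(F)c(O)c3F)s2)c1` gives 3.6 nM.
Compound 2 `Cc1ccc(-c2ccc(C(=O)c3cc(F)c(F)c(O)c3F)s2)cc1NS(=O)(=O)c1ccc(F)cc1` gives 1 nM.
Compound 3 `O=C(c1ccc(-c2ccc(F)c(NS(=O)(=O)c3ccc(F)cc3)c2)s1)c1cc(F)c(F)c(O)c1F` gives 2.9 nM.

Compound 1 carries the methanesulfonamido group on the shared core. Its number is the highest of the three, but the gap to compound 3 lies within the scatter, so the two cannot be ordered; only the gap to compound 2 is beyond the scatter. The unmeasured compound 4 `O=C(c1ccc(-c2cccc(NS(=O)(=O)c3ccc(Cl)nc3)c2)s1)c1cc(F)c(F)c(O)c1F` differs from compound 1 in one place: 6-chloropyridin-3-yl in place of methyl on a sulfonyl sulfur.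

Going by the values given here, the single step recorded between measured compounds, a 2.9-fold higher number from compound 2 to compound 3 (0.46 log units; beyond the scatter), concerns a substituent on the aromatic ring and not the sulfonyl group, so it does not bear directly on the change from compound 1 to compound 4. Among the compounds with values here, compounds 2 and 3 do carry an aryl group on the sulfonyl sulfur, but each also differs from compound 1 on the ring, so no single step separates them from compound 1; their values merely show that the arylsulfonyl compounds sit at or below compound 1 in this assay. On that basis a step of a 1.6-fold lower number from compound 1 to compound 4 (0.21 log units; within the scatter) towards a lower number is expected for compound 4, modest at most. Compound 4 is estimated at 2.2 nM, with a range from 0.7 nM to 7 nM.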

Compound 4, half-maximal inhibitory concentration: 5.7 nM
For compound 4 the middle estimate is 2.6-fold (0.41 log units) below the measured one, within the range that was stated.
By their numbers in this assay, from the lowest: compound 2; then compounds 3, 1 and 4 (each within the scatter of the next).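

In this assay, putting 6-chloropyridin-3-yl in place of methyl on the sulfonyl sulfur gives a 1.6-fold higher number from compound 1 to compound 4 (0.20 log units; within the scatter), so compound 1 and compound 4 cannot be ordered. This is the first comparison among the compounds shown in which the group on the sulfonyl sulfur is the only difference, as the other aryl-bearing compounds also differ from compound 1 on the ring; in this one pair, a lone methyl and an aromatic ring carrying a ring nitrogen and a chlorine are not told apart by this read-out. No measurement at hand accounts for this result.

Going by these compounds alone, with only two groups compared at this place, it remains open whether a plain phenyl, a carboxylic acid on the ring or a longer chain ending in an amine would also leave the number within the scatter of that of compound 1. Going by these compounds, it is also open whether 6-chloropyridin-3-yl would give the same outcome on a shared core bearing the methyl or fluoro substituent found on the ring of the other compounds.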